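This account rests on a few compounds, and the source may have more. Where it says the series, first, only, none or still open, it means among the compounds named here.

Measured compounds:
- compound 1, `CC(C)n1c(=O)[nH]c2ncc(Br)nc21`: "not determined" (no result reported)
- compound 2, `CCC(CC)n1c(=O)[nH]c2nccnc21`: "not determined" (no result reported)
- compound 3, `CCC(CC)n1c(=O)[nH]c2ncc(Cl)nc21`: 0.4

Three compounds sharing one core have been run through an ADME assay on microsomes from liver (Rattus norvegicus), read by LC-MS, with a stated time of 90 min (on this read-out lower numbers stand for lower hepatic extraction and higher numbers for higher hepatic extraction), yet only one of them returned a number. For compound 1 the result is recorded as "not determined" (no result reported), and for compound 2 likewise as "not determined" (no result reported), so neither gives a point of comparison. Compound 3 alone has a value: in this assay compound 3 gives 0.4. That places compound 3 in the lower-to-middle part of the scale. For the measured compounds named here, with no second number among the measured compounds, no step between measured compounds can be read, and compound 3 stands as the sole reference point.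

Compound 4, `CCC(CC)n1c(=O)[nH]c2ncc(OC)nc21`, is the next compound to be measured in this assay. It is built from compound 3 by one change, (methoxy in place of chloro on an aromatic carbon). Without any measured step of this kind in the set, the size of the effect is uncertain. A modest rise in this assay is expected, though a result within the usual scatter of compound 3 would not be surprising. The estimated step a number 0.10 higher from compound 3 to compound 4 (within the scatter) is expected to be small. For compound 4 a value of 0.5 is estimated, expected to lie between 0.3 and 0.7.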

Compound 4, hepatic extraction ratio: > 0.7
Compound 4: no number, only a limit; the forecaster's own chance of this, stated with the estimate: 5%; middle value at least 0.20 away from the limit.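

In this assay, methoxy in place of chloro on an aromatic carbon of the six-membered aromatic ring with 2 nitrogen gives a number at least 0.30 higher from compound 3 to compound 4 (beyond the scatter), which shows that this place on the shared core matters for hepatic extraction, something a set with a single number could not show. Compound 4 carries only a limit of the assay, not a number: the limit of > 0.7 in this assay, at which 1 of the 4 values shown sits. Exchanging one heavy atom for two, with one hydrogen-bond acceptor entering, is therefore enough to move this read-out beyond the usual scatter, although the data do not tell which feature of the change is responsible.

Steps involving compound 1 or compound 2 cannot be read, since neither has a number, so how a plain hydrogen in this place compares remains open and this one step makes no pattern. Also open, as far as these compounds go, is whether an amine, a nitrile or a longer ether such as ethoxy in this place would shift the read-out in the same way, and whether methoxy would do so with a different chain on the ring nitrogen.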